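Fluoro to Methoxy Swap on a Weakly Active Series

The source may hold more compounds than are shown below. What is called first, only, known or untested is meant among the compounds shown, and "the series" means these compounds.

Compound 1, `O=C(O)C1=Cc2ccccc2OC1(OCc1cc(-c2ccc(F)cc2F)no1)C(F)(F)F`, gives > 150000 nM in a functional assay on MCF7 cells (Homo sapiens) for inhibition, read by MTT assay, with a stated time of 24 h (on this read-out higher numbers stand for weaker inhibition and lower numbers for stronger inhibition), which is a limit of this assay rather than a number.
Compound 2, `O=C(O)C1=Cc2ccccc2OC1(OCc1cc(-c2ccc(F)cc2)no1)C(F)(F)F`, gives 64200 nM in this assay.

Among the measured compounds shown here, compound 2 holds the only actual number in this assay; the other value is a limit. For the measured compounds named here, the one measured step, an at least 2.3-fold lower number from compound 1 to compound 2 (0.36 log units; beyond the scatter), came from removing a fluoro, as noted for compound 1 at the limit of > 150000 nM in this assay, at which 1 of the 2 values shown sits. Compound 3, `COc1ccc(-c2cc(COC3(C(F)(F)F)Oc4ccccc4C=C3C(=O)O)on2)cc1`, differs from compound 2 by methoxy in place of fluoro on an aromatic carbon. Going by the values given here, no measured step concerns a fluoro-to-methoxy exchange, so there is nothing to project a direction from. The expectation is therefore a step of a 1.1-fold lower number from compound 2 to compound 3 (0.03 log units; within the scatter) in this assay, which stays within the scatter. Compound 3 is estimated at 60000 nM in this assay, with a range from 20000 nM to 150000 nM.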

Compound 3, half-maximal inhibitory concentration: 35200 nM
Compound 3: the middle estimate sits 1.7-fold (0.23 log units) above what was measured, and the stated range covers the measured number.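

In this assay, methoxy in place of fluoro on the aromatic carbon para to a large group gives a 1.8-fold lower number from compound 2 to compound 3 (0.26 log units; within the scatter), so this exchange cannot be told apart from repeat-measurement scatter, and the position accepts either group without a clear shift in the read-out. The broader comparison, 4-methoxyphenyl in place of 2,4-difluorophenyl, gives an at least 4.2-fold lower number from compound 1 to compound 3 (0.62 log units; beyond the scatter), which lies beyond the scatter. The true size of that step stays unknown, as compound 1 has only a limit and not a number: the limit of > 150000 nM in this assay, at which 1 of the 3 values shown sits.

Still open, as far as these compounds go, is whether a group such as an amine or a nitrile at this same position would move the number beyond the scatter. The compounds shown also leave open how an amide in place of the carboxylic acid on the shared core would read.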